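The compounds below may be only part of what the source reports. "The series", "measured", "known", "first", "only" and "open" are said of these compounds alone.

Compound 1 `COc1ccc(-c2ccc(-c3ccc(C(=N)N)cc3)s2)cc1` is the methoxy-bearing member of the set. For the measured compounds named here, in a functional assay on CAKI-1 cells (Homo sapiens) for inhibition, read by sulforhodamine B assay, with a stated time of 48 h (a lower number here means a stronger inhibitor of growth, a higher number a weaker inhibitor of growth), compound 1 gives 1500 nM, the second highest of the three numbers so far; compound 3 `COc1ccc(-c2ccc(-c3ccc(C(=N)N)c(F)c3)s2)cc1` gives 3940 nM and compound 2 `COc1cc(OC)cc(-c2ccc(-c3ccc(C(=N)N)c(F)c3)s2)c1` gives 233 nM. Going by the values given here, the one single-change step measured, a 2.6-fold higher number from compound 1 to compound 3 (0.42 log units; beyond the scatter), concerns fluorine on the far end of the shared core rather than the methoxy end. Compound 4 `N=C(N)c1ccc(-c2ccc(-c3ccc(Cl)cc3)s2)cc1` differs from compound 1 by chloro in place of methoxy on an aromatic carbon. Among the compounds with values here, no measured step bears on this change, so the series gives no direction for it; the expected step of no change at the digits printed from compound 1 to compound 4 (within the scatter) is therefore kept close to the scatter. For compound 4 the estimate in this assay is 1500 nM, with a range from 500 nM to 4500 nM.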

Compound 4, concentration for 50% growth inhibition: 167 nM
Compound 4: middle estimate off by 9.0-fold (0.95 log units), on the high side; measured number below the stated range.
By their numbers in this assay, from the lowest: compounds 4 and 2 (each within the scatter of the next); then compound 1; then compound 3.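

In this assay, for the compounds shown here, chloro in place of methoxy gives a 9.0-fold lower number from compound 1 to compound 4 (0.95 log units; beyond the scatter) and so provides the first reading at this end of the shared core. The group on this aromatic carbon, para to a large group, therefore moves the number beyond the scatter. No available data explain this step.

On these data alone, whether the shift comes from adding chloro or from losing methoxy remains open, and hydrogen, fluoro, methyl or trifluoromethyl here could separate the two. Also open, as far as these compounds go, is whether chloro gives a similar step on the fluoro-bearing core of compound 3.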